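From compound 3 to compound 4: a change on the carbonyl

The source may report more compounds than this note shows. Statements on the series, on what has been measured and on what is new or still open speak of the compounds shown alone.

In a physicochemical assay for lipophilicity, at pH 7.4 (on this read-out higher numbers stand for higher lipophilicity and lower numbers for lower lipophilicity), compound 1 (`CNC(=O)c1cc(C)n(Cc2cc(Cl)ccc2OCc2ccccc2)n1`) gives > 3.7, which is a limit and not a number. Compound 2 (`Cc1cc(C(=O)NCc2ccccc2)nn1Cc1cc(Cl)ccc1OCc1ccccc1`) gives > 3.7, again a limit. Within the data shown here, compound 3 (`Cc1cc(NC(=O)CC2CCCCC2)nn1Cc1cc(Cl)ccc1OCc1ccccc1`) gives 3.2, the only true number so far.

Compound 4 (`Cc1cc(NC(=O)C2CCCO2)nn1Cc1cc(Cl)ccc1OCc1ccccc1`) carries oxolan-2-yl in place of cyclohexylmethyl on a carbonyl carbon. Among the measured compounds shown here, no measured step isolates this change. The nearest are a number at least 0.50 log units lower from compound 1 to compound 3 (beyond the scatter) and a number at least 0.50 log units lower from compound 2 to compound 3 (beyond the scatter), both changing the group on the aromatic carbon, whereas a step that the two limits leave unreadable from compound 1 to compound 2 gives no usable size. These steps offer only a rough scale, so a modest fall is expected in this assay. The expected step is a number 0.50 log units lower from compound 3 to compound 4 (beyond the scatter). Compound 4 is estimated at 2.7, within a range of 2.2 to 3.2.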

Compound 4, distribution coefficient: > 3.7
Compound 4: no number, only a limit; the forecaster's own chance of this, stated with the estimate: 5%; middle value at least 1.00 log units from the limit.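

In this assay, the change on the carbonyl carbon gives a number at least 0.50 log units higher from compound 3 to compound 4 (beyond the scatter), with oxolan-2-yl in place of cyclohexylmethyl. Compound 4 gives > 3.7, which is a limit and not a number. The steps to compound 4 from compound 1 and from compound 2 cannot be read, and most of the series now rests on one limit: the limit of > 3.7 in this assay, at which 3 of the 4 values shown sit.

On these data alone, the full size of the step remains open, as does whether the oxygen of oxolan-2-yl or the loss of cyclohexylmethyl accounts for its direction. A cyclopentyl group on the same carbonyl carbon would separate these two changes.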